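A few compounds are considered here, and "the series" means these few. Any claim that something is new, unique, unknown or untested is made for them only; others in the source may bear on it.

Working notes on the series in a functional assay on HL-60 cells (Homo sapiens) for cytotoxicity, read by WST assay, with a stated time of 48 h; a lower number here means that less compound is needed, a higher number that more compound is needed for the effect: compound 1 (`CCCCOc1cccc(C[C@H]2C(=O)OC[C@@H]2Cc2ccccc2)c1`) gives 26000 nM, compound 2 (`CCCCCCCOc1cccc(C[C@H]2C(=O)OC[C@@H]2Cc2ccccc2)c1`) gives 81000 nM, and compound 3 (`Cc1cccc(C[C@H]2C(=O)OC[C@@H]2Cc2ccccc2)c1`) gives 53000 nM. Compound 3 holds the middle place of the three numbers. It cannot be separated from compound 2, as a 1.5-fold lower number from compound 2 to compound 3 (0.18 log units; within the scatter) shows, but it stands apart from compound 1, as a 2.0-fold higher number from compound 1 to compound 3 (0.31 log units; beyond the scatter) shows.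

The next change is trifluoromethyl in place of methyl on an aromatic carbon, giving compound 4 (`O=C1OC[C@H](Cc2ccccc2)[C@H]1Cc1cccc(C(F)(F)F)c1`): trifluoromethyl in place of methyl on an aromatic carbon. For the measured compounds named here, no measured step covers this exchange. The closest evidence is the replacement of alkoxy groups by methyl in the two steps above, and neither is large. The widest step in the set, a 3.1-fold higher number from compound 1 to compound 2 (0.49 log units; beyond the scatter), is also only modest. No clear direction can be drawn from these data, so no shift beyond the scatter is expected in this assay.

The expected step is a 1.2-fold lower number from compound 3 to compound 4 (0.07 log units; within the scatter). For compound 4 the estimated value is 45000 nM, with an expected range of 20000 nM to 100000 nM.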

Compound 4, half-maximal effective concentration: 34000 nM
Estimate against measurement, compound 4: 1.3-fold (0.12 log units) above; measured number inside the range.
By their numbers in this assay, from the lowest: compounds 1, 4, 3 and 2 (each within the scatter of the next, the first and the last beyond it).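

In this assay, trifluoromethyl on this aromatic carbon, meta to a large group, cannot be separated from methyl, with a 1.6-fold lower number from compound 3 to compound 4 (0.19 log units; within the scatter), or from butoxy, with a 1.3-fold higher number from compound 1 to compound 4 (0.12 log units; within the scatter). Heptyloxy is the only group shown that stands apart from trifluoromethyl, with a 2.4-fold lower number from compound 2 to compound 4 (0.38 log units; beyond the scatter), so this exchange adds a fluorine-bearing group to the series without a shift beyond the scatter from its methyl partner. Nothing available explains why these numbers fall as they do.

As far as these compounds go, it remains open whether a more different group at this place, such as an amine or a carboxylic acid, would move the number further than any step seen here. The compounds shown also leave open whether trifluoromethyl would behave the same way on another carbon of this ring or on the other benzene ring of the shared core.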